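Swapping a heptyl chain for phenyl on a triazole core

This account rests on a few compounds, and the source may have more. Where it says the series, first, only, none or still open, it means among the compounds named here.

Compound 1, `CCCCCCc1cn(C(c2ccccc2)c2ccccc2)nn1`, gives 14800 nM in an assay on isolated protein for inhibition of Aromatase (Homo sapiens), read by fluorescence and colorimetric assay, with a stated time of 30 min; on this read-out higher numbers stand for weaker inhibition and lower numbers for stronger inhibition. Compound 2, `CCCCCCCc1cn(C(c2ccccc2)c2ccccc2)nn1`, gives 19400 nM. Compound 3, `CCCCCCCCCCc1cn(C(c2ccccc2)c2ccccc2)nn1`, gives 13500 nM.

Compound 2 has the highest of the three numbers, but neither neighbour is separated from it by more than the scatter: the step of a 1.3-fold higher number from compound 1 to compound 2 (0.12 log units; within the scatter) and the step of a 1.4-fold lower number from compound 2 to compound 3 (0.16 log units; within the scatter) are both small, as is a 1.1-fold lower number from compound 1 to compound 3 (0.04 log units; within the scatter). Lengthening the saturated chain on the shared core therefore leaves this assay essentially unchanged across compounds 1, 2 and 3.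

Compound 4, `c1ccc(-c2cn(C(c3ccccc3)c3ccccc3)nn2)cc1`, differs from compound 2 by phenyl in place of heptyl on an aromatic carbon. Among the measured compounds shown here, none of the measured steps involves a ring in that place; all three only lengthen or shorten the chain, and all three stayed within the scatter. On that basis the chain itself seems to matter little, but a phenyl ring is a different kind of group, so the estimate rests on thin ground and carries a wide range. Compound 4 is expected to give about 15000 nM, between 4000 nM and 50000 nM, which means an expected step of a 1.3-fold lower number from compound 2 to compound 4 (0.11 log units; within the scatter).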

Compound 4, half-maximal inhibitory concentration: 12900 nM
Beside the measured number, compound 4's estimate is 1.2-fold (0.07 log units) above it, and the stated range covers the measured number.
By their numbers in this assay, from the lowest: compounds 4, 3, 1 and 2 (each within the scatter of the next).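

Until compound 4, only saturated chains had been seen at this aromatic carbon of the five-membered ring; now a six-membered aromatic ring of carbon only sits there. In this assay the swap of heptyl for phenyl gives a 1.5-fold lower number from compound 2 to compound 4 (0.18 log units; within the scatter) and the swap of hexyl for phenyl gives a 1.1-fold lower number from compound 1 to compound 4 (0.06 log units; within the scatter) on the same core, so here the read-out separates neither chain length nor a chain from a ring. Nothing available explains why these groups read alike.

Among the compounds shown here, every group at this position so far contains only carbon and hydrogen, so it remains open whether an amine or a carboxylic acid there would shift the number beyond the scatter. Also open, from the compounds shown here alone, is what a much shorter chain, such as methyl, or a phenyl ring carrying a fluorine would do.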